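The source may hold more compounds than are shown below. What is called first, only, known or untested is meant among the compounds shown, and "the series" means these compounds.

In an assay for inhibition of 3-hydroxy-3-methylglutaryl-coenzyme A reductase (Rattus norvegicus) (a higher number here means a weaker inhibitor, a lower number a stronger inhibitor), compound 2 `Cc1cc(C)c(/C=C/[C@@H]2C[C@@H](O)CC(=O)O2)c(-c2ccc(F)cc2)c1` gives 13 nM, the lowest of the two numbers in hand; compound 1 `O=C1C[C@H](O)C[C@@H](/C=C/c2c(F)cc(F)cc2-c2ccc(F)cc2)O1` gives 860 nM, a higher number beyond the scatter. Compound 3 `Cc1cc(C)c(/C=C/[C@@H]2C[C@@H](O)CC(=O)O2)c(-c2cc(C)c(F)c(C)c2)c1` is not yet measured. It differs from compound 2 by 4-fluoro-3,5-dimethylphenyl in place of 4-fluorophenyl on an aromatic carbon. For the measured compounds named here, no step between measured compounds of this kind exists, so the size of the change cannot be read off directly; a modest move toward a higher number, near the edge of the scatter, is expected. Compound 3 is expected to give 30 nM, within a range of 8 nM to 120 nM. The step expected is a 2.3-fold higher number from compound 2 to compound 3 (0.36 log units; beyond the scatter).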

Compound 3, half-maximal inhibitory concentration: 10 nM
Estimate against measurement, compound 3: 3.0-fold (0.48 log units) above; the measured number falls inside the stated range.
By their numbers in this assay, from the lowest: compounds 3 and 2 (each within the scatter of the next); then compound 1.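

In this assay, for the compounds shown here, the move to 4-fluoro-3,5-dimethylphenyl in place of 4-fluorophenyl gives a 1.3-fold lower number from compound 2 to compound 3 (0.11 log units; within the scatter) and is the first step readable at this position, on an aromatic carbon ortho to a large group. The position therefore accepts the larger dimethyl-substituted ring with the two compounds staying within the scatter of each other. Nothing at hand bears on why the values stay together.

Still open, as far as these compounds go, is whether this position accepts a ring carrying an amine or a carboxylic acid as well. How far a longer chain in place of the methyl groups would shift the number is also unsettled.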